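A Propargyl Ester Variant of Compound 1

This account rests on a few compounds, and the source may have more. Where it says the series, first, only, none or still open, it means among the compounds named here.

Compound 1 `C/C=C1/[C@H](O[C@@H]2O[C@H](COC(C)=O)[C@@H](OC(C)=O)[C@H](OC(C)=O)[C@H]2OC(C)=O)OC=C(C(=O)OC)[C@H]1CC(=O)OCCC` gives 6600 nM in a functional assay on SK-BR-3 cells (Homo sapiens) for antiproliferative activity, read by MTT assay, with a stated time of 72 h (a higher number here means a weaker inhibitor, a lower number a stronger inhibitor), the highest of the two numbers recorded here. Its nearest neighbour is compound 3 `C/C=C1/[C@H](O[C@@H]2O[C@H](COC(C)=O)[C@@H](OC(C)=O)[C@H](OC(C)=O)[C@H]2OC(C)=O)OC=C(C(=O)OC)[C@H]1CC(=O)OCCCCCCCCCCCCCCC`, which gives 3810 nM in this assay; the step of a 1.7-fold lower number from compound 1 to compound 3 (0.24 log units; within the scatter) stays within the scatter. Compound 2 `C/C=C1/[C@H](O[C@@H]2O[C@H](CO)[C@@H](O)[C@H](O)[C@H]2O)OC=C(C(=O)OC)[C@H]1CC(=O)OCCc1ccc(F)cc1` returns only the limit > 20000 nM in this assay, not a number. Compound 4 `C#CCOC(=O)C[C@@H]1C(C(=O)OC)=CO[C@@H](O[C@@H]2O[C@H](COC(C)=O)[C@@H](OC(C)=O)[C@H](OC(C)=O)[C@H]2OC(C)=O)/C1=C/C` differs from compound 1 in one place: ethynyl in place of ethyl on a saturated chain carbon bound to an oxygen next to a carbonyl group. For the measured compounds named here, the only measured step on this ester chain, from compound 1 to compound 3, did not move the number beyond the scatter, and no measured pair isolates an ethyl-to-ethynyl exchange. One therefore expects no step beyond the scatter. Compound 4 is estimated at 6000 nM, with a range from 2500 nM to 15000 nM. This estimate means an expected step of a 1.1-fold lower number from compound 1 to compound 4 (0.04 log units; within the scatter).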

Compound 4, half-maximal inhibitory concentration: > 15000 nM
Compound 4 gave a limit, no number (the forecaster's own chance of this, stated with the estimate: 15%); middle value at least 2.5-fold (0.39 log units) away from the limit.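

Compound 4 gives only a limit, not a number: the limit of > 15000 nM in this assay, at which 1 of the 4 values shown sits. Even so, in this assay the ester chain proves sensitive at this place, with ethynyl in place of ethyl giving an at least 2.2-fold higher number from compound 1 to compound 4 (0.35 log units; beyond the scatter) on the saturated chain carbon bound to an oxygen next to a carbonyl group. The earlier step on this chain, a 1.7-fold lower number from compound 1 to compound 3 (0.24 log units; within the scatter), had not shown this, so the position is not indifferent to what the chain carries.

Going by these compounds, the full size of the step stays open, as does whether the triple bond is what matters. An allyl ester, with a double bond at this place, or a chain ending in a nitrile would speak to that.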